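Adenosine-type nucleoside analogues at the edge of measurement

A few compounds are considered here, and "the series" means these few. Any claim that something is new, unique, unknown or untested is made for them only; others in the source may bear on it.

Compound 1 has the structure `Cc1ccc(CNc2ncnc3c2ncn3[C@@H]2O[C@H](CO)[C@@H](O)[C@H]2O)cc1`. In a functional assay on MCF cells (Homo sapiens) for antiproliferative activity, with a stated time of 72 h (on this read-out higher numbers stand for weaker inhibition and lower numbers for stronger inhibition), compound 1 gives > 166000 nM, which is a limit of the assay rather than a number. Going by the values given here, compound 2, `OC[C@H]1O[C@@H](n2cnc3c(NCc4c(F)ccc(F)c4F)ncnc32)[C@H](O)[C@@H]1O`, is the only other measured compound. In this assay compound 2 gives > 166000 nM, again a limit. Among the compounds with values here, the one measured step, a step that the two limits leave unreadable from compound 1 to compound 2, therefore tells nothing about size or direction, and the shared picture is the limit of > 166000 nM in this assay, at which 2 of the 2 values shown sit.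

Compound 3, `OC[C@H]1O[C@@H](n2cnc3c(NCc4cccc(C(F)(F)F)c4)ncnc32)[C@H](O)[C@@H]1O`, differs from compound 1 in one place: 3-(trifluoromethyl)phenyl in place of 4-methylphenyl on a saturated chain carbon bound to a nitrogen on an aromatic ring. Within the data shown here, no measured step shows what a trifluoromethyl-bearing phenyl does here, and the single step between the two measured compounds is unreadable. With both measured compounds sitting at the limit, compound 3 is expected to sit there as well, so the expected step that the limit leaves unreadable from compound 1 to compound 3 from compound 1 is one that would again fall outside what the assay can resolve. The estimate for compound 3 in this assay is 250000 nM, with a range from 60000 nM to 1000000 nM, and most likely only a limit will be reported.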

Compound 3, half-maximal inhibitory concentration: > 166000 nM
Compound 3: a limit, no number; the forecaster's own chance of this, stated with the estimate: 80%; the middle value does not contradict the limit.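

In this assay compound 3 gives > 166000 nM as a limit and not a number, and the steps joining compound 1, compound 2 and compound 3 cannot be read. The picture stays as it was: the limit of > 166000 nM in this assay, at which 3 of the 3 values shown sit.

The compounds shown leave open what actual value any of the three has, and whether either replacement of 4-methylphenyl changes antiproliferative activity at all.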